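The compounds below may be only part of what the source reports. "The series", "measured", "known", "first", "only" and "open" are said of these compounds alone.

Among the compounds with values here, in a functional assay on MCF7 cells (Homo sapiens) for antiproliferative activity, read by MTT assay, with a stated time of 48 h (on this read-out lower numbers stand for stronger inhibition and higher numbers for weaker inhibition), compound 2 `COc1ccc2nc(NC(c3cn(-c4ccccc4)nc3-c3ccc([N+](=O)[O-])cc3)c3c(O)ccc4ccccc34)sc2c1` gives 13300 nM, the lower of the two numbers measured so far. Within the data shown here, the only other measured compound, compound 1 `Cc1cc2nc(NC(c3cn(-c4ccccc4)nc3-c3ccc([N+](=O)[O-])cc3)c3c(O)ccc4ccccc34)sc2cc1C`, gives 41100 nM. Next comes compound 3 `Cc1ccc2nc(NC(c3cn(-c4ccccc4)nc3-c3ccc([N+](=O)[O-])cc3)c3c(O)ccc4ccccc34)sc2c1`, which has methyl in place of methoxy on an aromatic carbon. A single measured step bears on this change, and it also concerns the methoxy group: a 3.1-fold lower number from compound 1 to compound 2 (0.49 log units; beyond the scatter). Like compound 1, compound 3 carries methyl and no methoxy, but its group is 6-methyl-1,3-benzothiazol-2-yl rather than 5,6-dimethyl-1,3-benzothiazol-2-yl. One step is thin evidence, so only a partial return towards compound 1 seems reasonable. The expected move in this assay is a 1.8-fold higher number from compound 2 to compound 3 (0.26 log units; within the scatter), towards weaker inhibition and smaller than the measured step. The estimated value for compound 3 is 24000 nM, with a likely range from 11000 nM to 50000 nM.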

Compound 3, half-maximal inhibitory concentration: 20700 nM
Estimate against measurement, compound 3: 1.2-fold (0.06 log units) above; the measured number falls inside the stated range.
By their numbers in this assay, from the lowest: compounds 2, 3 and 1 (each within the scatter of the next, the first and the last beyond it).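

In this assay, 6-methyl-1,3-benzothiazol-2-yl in place of 6-methoxy-1,3-benzothiazol-2-yl gives only a small shift (a 1.6-fold higher number from compound 2 to compound 3 (0.19 log units; within the scatter)), so at this place the two groups cannot be told apart by this read-out. Hydrogen in place of methyl on an aromatic carbon also stays small (a 2.0-fold lower number from compound 1 to compound 3 (0.30 log units; within the scatter)), which means the clear gap between compounds 1 and 2 is now bridged by two steps, neither of them beyond the scatter. Nothing given here explains these numbers.

The three compounds shown leave open how a chlorine atom, a hydroxyl group or an amine would read at this place. They also leave open whether a larger shift would appear with a group such as a carboxylic acid.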